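This account rests on a few compounds, and the source may have more. Where it says the series, first, only, none or still open, it means among the compounds named here.

Compound 1 `O=C(CCCCCN(C(=O)c1ccccc1)C1(C(=O)NC2CCCCC2)CCCCC1)NO` gives 42600 nM
Compound 2 `CN(C)c1ccc(C(=O)N(CCCCCC(=O)NO)C(C)(C)C(=O)NC2CCCCC2)cc1` gives 68500 nM
Compound 3 `CN(C)c1ccc(C(=O)N(CCCCCC(=O)NO)CC(=O)NC2CCCCC2)cc1` gives 1540 nM

All three values come from a functional assay on A2780 cells (Homo sapiens) for cytotoxicity, read by MTT assay, with a stated time of 72 h (on this read-out lower numbers stand for stronger inhibition and higher numbers for weaker inhibition), and no more. Compound 2, at 68500 nM in this set, sits at the weak end together with compound 1, the two lying within the scatter of each other. Compound 3 lies beyond the scatter from compound 2, with a much lower number.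

Compound 4 `CC(C)(C(=O)NC1CCCCC1)N(CCCCCC(=O)NO)C(=O)c1ccccc1` has not yet been measured. It differs from compound 2 by hydrogen in place of dimethylamino on an aromatic carbon in one place: hydrogen in place of dimethylamino on an aromatic carbon, so that 4-(dimethylamino)phenyl becomes phenyl. Within the data shown here, no measured pair isolates this change. Compound 1 also carries benzoyl, and its 42600 nM stays within the scatter of compound 2, so no step beyond the scatter is expected in this assay here. The estimated 1.4-fold lower number from compound 2 to compound 4 (0.14 log units; within the scatter) is therefore small. For compound 4 the expected value is 50000 nM with an estimated range from 20000 nM to 120000 nM in all.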

Compound 4, half-maximal inhibitory concentration: 295000 nM
Estimate against measurement, compound 4: 5.9-fold (0.77 log units) below; the whole stated range lies below it.
By their numbers in this assay, from the lowest: compound 3; then compounds 1 and 2 (each within the scatter of the next); then compound 4.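

In this assay, hydrogen in place of dimethylamino on an aromatic carbon gives a 4.3-fold higher number from compound 2 to compound 4 (0.63 log units; beyond the scatter), and this pair is the only one shown that isolates the change. It shows that, on the core of compound 2, this position para to a large group is not indifferent to its substituent: the 4-(dimethylamino)phenyl compound keeps the lower number, and phenyl does not match it. No measurement at hand bears on why the number rises with this change.

From the compounds shown here alone, whether a different group at this position, such as methoxy or a plain amino group, would hold the number down as dimethylamino does remains open. Also open, going by these compounds, is whether the same change would have a step of similar size on the core of compound 3.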